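The source may hold more compounds than are shown below. What is called first, only, known or untested is meant among the compounds shown, and "the series" means these compounds.

Working notes on the series. In a functional assay on MCF7 cells (Homo sapiens) for inhibition, read by colorimetric assay and MTT assay, with a stated time of 72 h (a higher number here means a weaker inhibitor, a lower number a stronger inhibitor), compound 1 `C=CCCCCOc1cc2ccccc2cc1-c1cnc(OCCCCC=C)n1C` gives 37000 nM, compound 2 `CCCCOc1ncc(-c2ccccc2OC)n1C` gives 55000 nM and compound 3 `C#CCCCCOc1ncc(-c2ccccc2OC)n1C` gives 10000 nM, the lowest of the three numbers. Compound 4 `C=CCCCCOc1ncc(-c2ccccc2OC)n1C` carries vinyl in place of ethynyl on a saturated chain carbon, four bonds along the chain from an oxygen on an aromatic ring. Among the compounds with values here, the one measured step at this place is a 5.5-fold lower number from compound 2 to compound 3 (0.74 log units; beyond the scatter), with ethynyl in place of hydrogen. Within the data shown here, no measured pair compares vinyl with ethynyl directly. A modest rise in this assay, smaller than that measured step, is therefore expected: a 2.0-fold higher number from compound 3 to compound 4 (0.30 log units; within the scatter). Compound 4 is estimated at 20000 nM, with an expected range of 8000 nM to 50000 nM.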

Compound 4, half-maximal inhibitory concentration: 5000 nM
For compound 4 the middle estimate is 4.0-fold (0.60 log units) above the measured one, outside the stated range (below it).
By their numbers in this assay, from the lowest: compounds 4 and 3 (each within the scatter of the next); then compounds 1 and 2 (each within the scatter of the next).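

In this assay the swap at this chain end gives a 2.0-fold lower number from compound 3 to compound 4 (0.30 log units; within the scatter), so vinyl and ethynyl are not told apart at this position. Set against the hydrogen of compound 2, vinyl gives an 11-fold lower number from compound 2 to compound 4 (1.04 log units; beyond the scatter), a large step, so both unsaturated ends stand clear of the saturated chain. Nothing at hand speaks to the reason for this. Open, as far as these compounds go, is whether an amine, a carboxylic acid or a longer chain at this place would hold that level, and whether the vinyl step carries over to the core of compound 1.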